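Bromo for methyl: from compound 2 to compound 3

A few compounds are considered here, and "the series" means these few. Any claim that something is new, unique, unknown or untested is made for them only; others in the source may bear on it.

Two compounds of this series carry a number in a functional assay on MCF7 cells (Homo sapiens) for inhibition, read by MTT assay, with a stated time of 48 h, tested at 7.5 ug/mL; on this read-out lower numbers stand for less inhibition of growth and higher numbers for more inhibition of growth at the one concentration tested. Compound 1 `Cc1cc(C)c2c(c1)CN(c1ccc3c(=O)cc(-c4ccccc4)oc3c1)CO2` gives 11.3%, and compound 2 `Cc1cccc2c1OCN(c1ccc3oc(-c4ccccc4)cc(=O)c3c1)C2` gives 30.4%, the highest of the two, with compound 1 standing a gap lower that exceeds the usual scatter. Compound 3 `O=c1cc(-c2ccccc2)oc2ccc(N3COc4c(Br)cccc4C3)cc12` is not yet measured; relative to compound 2 the change is bromo in place of methyl on an aromatic carbon. Within the data shown here, no pair of measured compounds differs in one place, so the size of such a swap is not known from the series, and compound 1 and compound 2 differ in more than one place. With nothing to anchor a direction, the expected step of a number 0.4 percentage points lower from compound 2 to compound 3 (within the scatter) is set at none beyond the scatter. Compound 3 is thus estimated at 30%, with a range from 12% to 50%.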

Compound 3, percent growth inhibition at one concentration: "not active" (no number reported)
For compound 3 the study gives words and no number; there is nothing to compare the estimate with.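

In this assay, among these compounds, compound 3 is reported in words only, so no step from compound 2 to compound 3 can be read. Nothing shown bears on a cause for this result. The compounds shown leave open how large a change bromo in place of methyl brings.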